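A few compounds are considered here, and "the series" means these few. Any claim that something is new, unique, unknown or untested is made for them only; others in the source may bear on it.

Measured compounds:

Compound 1 `COc1ccc(-c2c(C)sc3c(N4CC[C@@H](NC(C)=O)C4)nc(C)nc23)cc1OC`; in an ADME assay on microsomes from liver (Homo sapiens) for metabolic stability, read by LC-MS, with NADPH named in the record, with a stated time of 60 min, tested at 1 uM, in the absence of a further agent (a lower number here means that less of the compound is left, a higher number that more of the compound is left), compound 1 gives > 95%, which is a limit of the assay and not a number.
Compound 2 `CC(=O)N[C@@H]1CCN(c2cc(C)nn3c(-c4ccc(OC(F)(F)F)cc4)c(C)nc23)C1`; compound 2 gives > 95%, again a limit of the assay.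
Compound 3 `COc1ccc(-c2c(C)nc3c(N4CC[C@@H](NC(=O)c5ccccc5)C4)cc(C)nn23)cc1OC`; compound 3 gives > 95%, also a limit of the assay.

Where compound 3 stands is therefore only at the upper edge of what the assay reports, and it is not alone there: the limit of > 95% in this assay, at which 3 of the 3 values shown sit. Going by the values given here, no step between measured compounds can be sized from these data, since every measured value is a limit.

The next compound in the series is compound 4 `COc1ccc(-c2c(C)nc3c(N4CC[C@@H](NS(=O)(=O)c5ccc(C(C)=O)cc5)C4)cc(C)nn23)cc1OC`, not yet measured. It differs from compound 3 in one place: (4-acetylphenyl)sulfonyl in place of benzoyl on an amine nitrogen.

Among the compounds with values here, with every measured compound sitting at the same limit, and with no step to show how a change on that amine nitrogen moves the read-out, the expectation for the step from compound 3 to compound 4 is one of no change beyond the scatter, i.e. a number at least 3 percentage points lower from compound 3 to compound 4 (that floor lies within the scatter). Compound 4 is accordingly estimated to remain near the upper limit, with an estimate of 92% and a range from 75% to 99%, the most likely outcome being that the assay again reports only the limit.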

Compound 4, percent of the compound remaining: > 95%
Compound 4: only a limit was reported; the forecaster's own chance of this, stated with the estimate: 55%; at least 3 percentage points between middle value and limit.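

Compound 3 and compound 4 both stand at a limit of this assay, so the step from benzoyl to (4-acetylphenyl)sulfonyl on the amine nitrogen cannot be read. The series offers no readable comparison: the limit of > 95% in this assay, at which 4 of the 4 values shown sit.

The compounds shown leave open how far any change in the series would move the compound remaining, as none has a value below that limit.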